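The source may hold more compounds than are shown below. What is called first, only, known or untested is meant among the compounds shown, and "the series" means these compounds.

The compound at the center here is compound 2 `CCc1sc(CCc2cc(OC3CCCCC3)cc(NCc3cc(Cl)cc(NC(=O)OC(C)C)c3)n2)nc1C`, which in an assay on cells for binding affinity to Neuropeptide Y receptor type 1 (Homo sapiens) (on this read-out higher numbers stand for weaker inhibition and lower numbers for stronger inhibition), gives 29 nM. Among the measured compounds shown here, only one other compound has been measured alongside it, compound 1 `CCOc1cc(CCc2nc(C)c(CC)s2)nc(NCc2cc(Cl)cc(NC(=O)OC(C)C)c2)c1`, which in this assay gives 33 nM. Compound 2 nominally holds the lower of the two numbers, but the step of a 1.1-fold lower number from compound 1 to compound 2 (0.06 log units; within the scatter) is within the scatter, so the two results cannot be told apart.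

The next compound, compound 3 `CCc1sc(CCc2cc(OCCCc3ccccc3)cc(NCc3cc(Cl)cc(NC(=O)OC(C)C)c3)n2)nc1C`, differs from compound 2 in one place: 3-phenylpropyl in place of cyclohexyl on an oxygen on an aromatic ring. For the measured compounds named here, only one measured step bears on this position, the exchange of groups on the same oxygen that separates compound 1 from compound 2, and that step, a 1.1-fold lower number from compound 1 to compound 2 (0.06 log units; within the scatter), did not rise above the scatter. Going by the values given here, with a single step of that size as the only guide, the expected change from compound 2 to compound 3 is a 1.2-fold higher number from compound 2 to compound 3 (0.08 log units; within the scatter), a step of no clear direction and none beyond the scatter. For compound 3 the estimated value in this assay is 35 nM, with a range from 12 nM to 100 nM.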

Compound 3, half-maximal inhibitory concentration: 20 nM
For compound 3 the middle estimate is 1.8-fold (0.24 log units) above the measured one; the measured number falls inside the stated range.
By their numbers in this assay, from the lowest: compounds 3, 2 and 1 (each within the scatter of the next).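

Across the three groups on this oxygen, this assay now gives the step of a 1.5-fold lower number from compound 2 to compound 3 (0.16 log units; within the scatter) and the step of a 1.7-fold lower number from compound 1 to compound 3 (0.22 log units; within the scatter) and both stay within the scatter. The earlier pair showed only that ethyl and cyclohexyl could not be told apart; the new result extends this to 3-phenylpropyl, which has 9 heavy atoms against 6 for cyclohexyl and carries an aromatic ring at the end of a chain instead of a non-aromatic ring sitting directly on the oxygen. So in these three compounds, neither the larger group nor the aromatic ring moves the number beyond the scatter, and no information is available here to explain why this position shows so little response.

As far as these compounds go, all three groups on this oxygen are built from carbon and hydrogen alone, so it remains open whether the number would also hold with an amine or a carboxylic acid at the end of the chain. From the compounds shown here alone, it is equally open whether a longer chain, or a phenyl ring with substituents of its own, would finally produce a step that rises above the scatter.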